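A few compounds are considered here, and "the series" means these few. Any claim that something is new, unique, unknown or untested is made for them only; others in the source may bear on it.

Two close relatives have been tested in an ADME assay on MCF-10A cells (Homo sapiens) for cytotoxicity, read by MTT assay, with a stated time of 48 h; on this read-out lower numbers stand for stronger inhibition and higher numbers for weaker inhibition. Compound 1 `COc1cc(C#N)ccc1OCc1nnc(-c2ccc(C)cc2)o1` gives > 100000 nM, which is a limit of the assay and not a number. Compound 2 `COc1cc(C#N)ccc1OCc1nnc(-c2ccc(F)cc2)o1` gives > 100000 nM, which is also a limit and not a number. Compound 2 therefore has no exact figure to start from, and the evidence so far is the limit of > 100000 nM in this assay, at which 2 of the 2 values shown sit.

The next compound, compound 3 `COc1cc(C#N)ccc1OCc1nnc(-c2ccc(Cl)cc2)o1`, differs from compound 2 in one place: chloro in place of fluoro on an aromatic carbon. In words, this is chloro in place of fluoro on an aromatic carbon, para to a large group.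

Among the compounds with values here, only one measured comparison bears on this change, a step that the two limits leave unreadable from compound 1 to compound 2, in which fluoro took the place of methyl on an aromatic carbon. It offers neither a size nor a direction to carry over. With nothing pointing either way, no change beyond the usual scatter is expected in this assay, and the expected step is a number no higher from compound 2 to compound 3 (the limit leaves the size open).

For compound 3, the estimated value is 100000 nM, with an expected range from 50000 nM to 200000 nM.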

Compound 3, half-maximal inhibitory concentration: 89500 nM
Compound 3: the middle estimate sits 1.1-fold (0.05 log units) above what was measured; low and high end bracket the measured number.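

In this assay, within the data shown here, compound 3 is the first of these close relatives to give an exact figure, so the change at this position can now be given a direction, though only as a lower bound on its size. Going from 4-fluorophenyl to 4-chlorophenyl gives an at least 1.1-fold lower number from compound 2 to compound 3 (0.04 log units; that floor lies within the scatter), and chloro in place of methyl on the same aromatic carbon gives an at least 1.1-fold lower number from compound 1 to compound 3 (0.04 log units; that floor lies within the scatter). Each of these steps is only a floor that starts from a limit, so the true size remains unknown and may be no larger than ordinary repeat variation; the step between compound 1 and compound 2 cannot be read at all, and most of the series still sits at one ceiling: the limit of > 100000 nM in this assay, at which 2 of the 3 values shown sit.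

The compounds shown leave open whether a bromo, a methoxy or an amine at this same place would give an exact figure, and how far that figure would lie from the one for compound 3. They also leave open whether the nitrile or the methoxy on the other aromatic ring of the shared core contributes to the result, since both stay the same throughout.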